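A few compounds are considered here, and "the series" means these few. Any claim that something is new, unique, unknown or untested is made for them only; others in the source may bear on it.

In a functional assay on BGC-823 cells (Homo sapiens) for cytotoxicity, read by MTT assay, with a stated time of 48 h (a higher number here means a weaker inhibitor, a lower number a stronger inhibitor), compound 1 (`O=C(CSc1nnc(-c2ccncc2)o1)N/N=C/c1ccccc1[N+](=O)[O-]`) gives 41600 nM and compound 2 (`O=C(CSc1nnc(-c2ccncc2)o1)N/N=C/c1cc(Cl)cc(Cl)c1O`) gives 6340 nM as its value, while compound 3 (`O=C(CSc1nnc(-c2ccncc2)o1)N/N=C/c1ccc(O)c(O)c1`) gives 1260 nM as the lowest number of the three. Compound 4 (`O=C(CSc1nnc(-c2ccncc2)o1)N/N=C/c1ccco1`) keeps the shared core and swaps one group, furan-2-yl in place of 3,4-dihydroxyphenyl on a carbon with a double bond to nitrogen is the counted difference. For the measured compounds named here, no measured compound carries furan-2-yl, so the only guide is two steps that arrive at 3,4-dihydroxyphenyl: a 5.0-fold lower number from compound 2 to compound 3 (0.70 log units; beyond the scatter) and a 33-fold lower number from compound 1 to compound 3 (1.52 log units; beyond the scatter) are what was measured. Giving that group up is therefore expected to raise the number in this assay by a modest step. The expected step is a 7.1-fold higher number from compound 3 to compound 4 (0.85 log units; beyond the scatter) by this estimate. For compound 4 the estimated value is 9000 nM with an expected range from 2500 nM to 35000 nM in repeat measurements.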

Compound 4, half-maximal inhibitory concentration: 25800 nM
Compound 4: the middle estimate sits 2.9-fold (0.46 log units) below what was measured, within the range that was stated.
By their numbers in this assay, from the lowest: compound 3; then compound 2; then compounds 4 and 1 (each within the scatter of the next).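

In this assay, the ring on the carbon with a double bond to nitrogen clearly matters: furan-2-yl gives a 20-fold higher number from compound 3 to compound 4 (1.31 log units; beyond the scatter), and a smaller but still clear a 4.1-fold higher number from compound 2 to compound 4 (0.61 log units; beyond the scatter). Against 2-nitrophenyl, furan-2-yl makes no real difference, with a 1.6-fold lower number from compound 1 to compound 4 (0.21 log units; within the scatter), which lies within the scatter. Thus the two hydroxy-bearing rings, in compound 2 and compound 3, give the lower numbers among these four compounds.

Nothing available explains these differences. Going by these compounds, whether an amine or a carboxylic acid on the ring would keep or lower the number remains open.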